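Moving the Free Hydroxyl One Carbon Further Out

The source may hold more compounds than are shown below. What is called first, only, known or untested is meant among the compounds shown, and "the series" means these compounds.

Compound 2 `COCCOc1cc2c(NC3CCCCC3)ncnc2cn1` gives 101 nM in a functional assay on CHO cells for antagonist activity at metabotropic glutamate receptor 1 (Rattus norvegicus), with a stated time of 5 min; a higher number here means a weaker inhibitor, a lower number a stronger inhibitor; it holds the lower of the two numbers shown, though the gap is within the scatter: compound 1 `OCCOc1cc2c(NC3CCCCC3)ncnc2cn1` gives 177 nM, and a 1.8-fold lower number from compound 1 to compound 2 (0.24 log units; within the scatter). Compound 3 `OCCCOc1cc2c(NC3CCCCC3)ncnc2cn1` differs from compound 2 by hydroxymethyl in place of methoxy on a saturated chain carbon, two bonds along the chain from an oxygen on an aromatic ring, so the free hydroxyl seen in compound 1 returns on a chain one carbon longer. Within the data shown here, the single step at hand stayed within the scatter, so the step expected in this assay is a 1.5-fold higher number from compound 2 to compound 3 (0.17 log units; within the scatter), nothing beyond the scatter. Compound 3 is estimated at 150 nM, with a range from 60 nM to 400 nM.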

Compound 3, inhibition constant: 33 nM
Beside the measured number, compound 3's estimate is 4.5-fold (0.66 log units) above it, and the stated range ends above it.
By their numbers in this assay, from the lowest: compound 3; then compounds 2 and 1 (each within the scatter of the next).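

In this assay this change on the chain goes beyond the scatter, with a 3.1-fold lower number from compound 2 to compound 3 (0.49 log units; beyond the scatter) and a 5.4-fold lower number from compound 1 to compound 3 (0.73 log units; beyond the scatter) as the two steps that do so. Compound 2 and compound 3 have the same atoms, so only their arrangement separates them, and compound 1 shows that a free hydroxyl on the shorter chain does not by itself give the lowest number. No available evidence explains this gain. Still open, going by these compounds, is whether a 4-hydroxybutoxy chain goes further, and whether an amine or a carboxylic acid at the chain end could replace the hydroxyl.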